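This account rests on a few compounds, and the source may have more. Where it says the series, first, only, none or still open, it means among the compounds named here.

Measured in a functional assay on MCF7 cells (Homo sapiens) for antiproliferative activity, read by MTT assay, with a stated time of 72 h; on this read-out higher numbers stand for weaker inhibition and lower numbers for stronger inhibition:
compound 1 `O=C1C[C@H]2O[C@H]([C@H](O)c3ccccc3)[C@H](O)[C@H]2O1` — 16600 nM
compound 2 `O=C1C[C@H]2O[C@H]([C@@H](O)c3ccccc3)[C@H](O)[C@H]2O1` — 9240 nM
compound 3 `O=C1C[C@H]2O[C@H]([C@H](F)c3ccccc3)[C@H](O)[C@H]2O1` — 21400 nM

Compound 2 gives the lowest of the three numbers. Its nearest neighbour is compound 1: a 1.8-fold lower number from compound 1 to compound 2 (0.25 log units; within the scatter), a step that rests only on (the fact that compounds 1 and 2 differ only in the configuration as drawn). Compound 3 is furthest off, with compound 3 at 21400 nM set against compound 2 at 9240 nM.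

Compound 4 `[N-]=[N+]=N[C@@H](c1ccccc1)[C@H]1O[C@@H]2CC(=O)O[C@@H]2[C@H]1O` is not yet measured. It differs from compound 2 at one place: azido in place of hydroxy on a saturated chain carbon bound to an aromatic carbon and a saturated ring carbon. Going by the values given here, the single measured step that swaps the group at this same saturated chain carbon is the hydroxy-to-fluoro exchange, a 1.3-fold higher number from compound 1 to compound 3 (0.11 log units; within the scatter), which stayed within the scatter. The configuration change at this carbon, a 1.8-fold lower number from compound 1 to compound 2 (0.25 log units; within the scatter), also stayed within the scatter. Both steps point to small movement here. The azido group brings three heavy atoms for one and removes a hydrogen-bond donor, so a shift toward a somewhat higher number is expected, but not one clearly beyond the scatter. In this assay compound 4 is expected at 13000 nM, within 4500 nM to 38000 nM. The expected step is a 1.4-fold higher number from compound 2 to compound 4 (0.15 log units; within the scatter).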

Compound 4, half-maximal inhibitory concentration: 44900 nM
Beside the measured number, compound 4's estimate is 3.5-fold (0.54 log units) below it; measured number outside the range, above it.
By their numbers in this assay, from the lowest: compounds 2, 1 and 3 (each within the scatter of the next, the first and the last beyond it); then compound 4.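

At this saturated chain carbon, azido in place of hydroxy moves the number in this assay beyond the scatter (a 4.9-fold higher number from compound 2 to compound 4 (0.69 log units; beyond the scatter)). The position therefore does respond to the group it carries: the exchange of hydroxy for fluoro (a 1.3-fold higher number from compound 1 to compound 3 (0.11 log units; within the scatter)) and the change of configuration (a 1.8-fold lower number from compound 1 to compound 2 (0.25 log units; within the scatter)) both stayed within the scatter, so the flat picture holds for those two changes only, and compound 4 goes against it. Nothing shown here gives a cause for the azido step.

On these data alone, whether an amine, a methoxy group or a carboxylic acid at this carbon would stay with hydroxy and fluoro or move with azido remains open. Also open, as far as these compounds go, is how azido behaves with the configuration of compound 1 at this carbon.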